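The compounds below may be only part of what the source reports. "The series", "measured", "known", "first", "only" and "open" are said of these compounds alone.

In a functional assay on HEp-2 cells (Homo sapiens) for cytotoxicity, read by MTT assay, with a stated time of 72 h (on this read-out lower numbers stand for stronger inhibition and higher numbers for weaker inhibition), compound 1 `Cc1ccc2oc(CSc3nnc(C)s3)cc(=O)c2c1` gives only a limit, > 25000 nM. Compound 2 `Cc1ccc2oc(CSc3nnc(N)s3)cc(=O)c2c1` likewise reaches only a limit, > 25000 nM. Compound 3 `Nc1nnc(SCc2coc3ccccc3c2=O)s1` has a core that differs from that of compound 2 in a way not broken down here. Compound 3 gives 1500 nM, the only plain number among these three results. The change from compound 2 to compound 1 is methyl in place of amino on an aromatic carbon; its size stays unreadable, a step that the two limits leave unreadable from compound 2 to compound 1, since both values sit at a limit (the limit of > 25000 nM in this assay, at which 2 of the 3 values shown sit). Compound 4 `Cc1nnc(SCc2coc3ccccc3c2=O)s1` carries the same change against compound 3: methyl in place of amino on an aromatic carbon. The measured pair gives no size to lean on, and the step from compound 3 to compound 4 is expected to be modest, a 2.0-fold higher number from compound 3 to compound 4 (0.30 log units; within the scatter). Compound 4 is therefore estimated at 3000 nM, expected to fall between 1000 nM and 12000 nM.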

Compound 4, half-maximal inhibitory concentration: 2900 nM
For compound 4 the middle estimate is 1.0-fold (0.01 log units) above the measured one; low and high end bracket the measured number.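

In this assay, putting methyl in place of amino on the core of compound 3 gives a 1.9-fold higher number from compound 3 to compound 4 (0.29 log units; within the scatter), so on this core the change has no effect that can be told apart from the scatter. The same change from compound 2 to compound 1 cannot be read, because both values are limits and not numbers: the limit of > 25000 nM in this assay, at which 2 of the 4 values shown sit.

This leaves one sized step on one core, which neither supports nor rules out a similar result on the other core. As far as these compounds go, whether a different group at this place, such as an ethyl chain, a dimethylamino group or a carboxylic acid, would shift the number beyond the scatter stays open. Also open, from the compounds shown here alone, is how compound 1 and compound 2 would compare if either gave a plain number.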